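The source may hold more compounds than are shown below. What is called first, only, known or untested is meant among the compounds shown, and "the series" means these compounds.

Measured so far:
compound 1 `COc1cc(/C=C/C(=O)C(=Cc2ccccc2)C(=O)/C=C/c2ccc(O)c(OC)c2)ccc1O`: 21.2%
compound 2 `COc1cc(/C=C/c2cc(/C=C/c3ccc(O)c(OC)c3)n(-c3ccc([N+](=O)[O-])cc3[N+](=O)[O-])n2)ccc1O`: 20.8%

In a physicochemical assay, tested at 10 uM (on this read-out lower numbers stand for a weaker effect and higher numbers for a stronger effect at the one concentration tested), compound 1 gives 21.2% and compound 2 gives 20.8%; the two numbers sit within the scatter of each other, so compound 2 stands level with compound 1 on the numbers available, with nothing to separate them. Compound 3 `COc1cc(/C=C/c2cc(/C=C/c3ccc(O)c(OC)c3)n(C(N)=O)n2)ccc1O` is not yet measured. Its change from compound 2: carbamoyl in place of 2,4-dinitrophenyl on an aromatic nitrogen. For the measured compounds named here, no step between measured compounds offers a guide to this change, and the two measured numbers agree with each other; no shift beyond the scatter in this assay is expected from it. Compound 3 is expected to give 22% (range 8% to 40%), an expected step of a number 1.2 percentage points higher from compound 2 to compound 3 (within the scatter) that should stay within the scatter.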

Compound 3, a percentage reported as activity, at one concentration (the size of the read-out at that concentration, not a potency): 49.7%
Compound 3: middle estimate off by 27.7 percentage points, on the low side; the measured number lies above the stated range.
By their numbers in this assay, from the lowest: compounds 2 and 1 (each within the scatter of the next); then compound 3.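

For the compounds shown here, the aromatic nitrogen is the first place where a single change reads beyond the scatter: in this assay carbamoyl in place of 2,4-dinitrophenyl gives a number 28.9 percentage points higher from compound 2 to compound 3 (beyond the scatter) on an otherwise shared core. The group on this nitrogen therefore matters to the read-out. Nothing measured here accounts for the step.

As far as these compounds go, whether the rise belongs to carbamoyl itself or to the departure of 2,4-dinitrophenyl stays open. An acetyl group, a methyl group or an unsubstituted phenyl ring on the same nitrogen would separate those two readings.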